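The compounds below may be only part of what the source reports. "The series", "measured", "known", "first", "only" and "open" are said of these compounds alone.

Compound 1 `CCCCC[Se]c1nc(N)c2ccccc2n1` is the series anchor. Among the measured compounds shown here, in a functional assay on CCRF-CEM cells (Homo sapiens) for cytotoxicity, read by MTT assay, with a stated time of 72 h (on this read-out lower numbers stand for stronger inhibition of growth and higher numbers for weaker inhibition of growth), compound 1 gives 68000 nM, the only full number in hand. Compound 2 `COc1ccc(CNc2nc([SeH])nc3ccccc23)cc1` in this assay gives > 100000 nM, which is a limit of the assay and not a number (the limit of > 100000 nM in this assay, at which 1 of the 2 values shown sits). Compound 3 `C[Se]c1nc(N)c2ccccc2n1` is not yet measured; it differs from compound 1 by hydrogen in place of butyl on a saturated chain carbon bound to a selenium atom, pentyl to methyl. For the measured compounds named here, no measured step connects two compounds here, so the expected step in this assay rests on the shortening alone and is taken as a modest loss, probably not beyond the scatter; the step expected from compound 1 to compound 3 is a 1.3-fold higher number from compound 1 to compound 3 (0.12 log units; within the scatter). Compound 3 is estimated at 90000 nM, with a range from 30000 nM to 250000 nM.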

Compound 3, concentration for total growth inhibition: > 100000 nM
Compound 3: only a limit was reported; the forecaster's own chance of this, stated with the estimate: 40%; middle value at least 1.1-fold (0.04 log units) from the limit.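

In this assay, hydrogen in place of butyl on a saturated chain carbon bound to a selenium atom gives an at least 1.4-fold higher number from compound 1 to compound 3 (0.16 log units; that floor lies within the scatter), a floor and not a full size of step. Of the two chain lengths on selenium, only pentyl gives a full number; the value of compound 3 is a limit of the assay. The series now gathers at the top of the range: the limit of > 100000 nM in this assay, at which 2 of the 3 values shown sit.

As far as these compounds go, whether a longer chain such as octyl, or a benzyl group, on the selenium atom would give a lower number stays open. From the compounds shown here alone, the real distance between methyl and pentyl also remains unknown.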